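This account rests on a few compounds, and the source may have more. Where it says the series, first, only, none or still open, it means among the compounds named here.

In a functional assay on A549 cells (Homo sapiens) for antiproliferative activity, read by MTT assay, with a stated time of 72 h (on this read-out lower numbers stand for stronger inhibition and higher numbers for weaker inhibition), compound 1 `C/C=C/C(=O)Nc1cccc(Oc2nc(Nc3ccn(C)n3)nc3c2CSCC3)c1` gives > 50000 nM, which is a limit of the assay and not a number. Within the data shown here, compound 2 `C/C=C/C(=O)Nc1cccc(Oc2nc(Nc3cccc(OC)c3)nc3c2CSCC3)c1` gives 21100 nM, the only actual number so far. Among the measured compounds shown here, the single measured step is an at least 2.3-fold lower number from compound 1 to compound 2 (0.37 log units; beyond the scatter). It lies beyond the scatter, but it concerns the group on a nitrogen on an aromatic ring, not the chain that changes next. Compound 3 `COc1cccc(Nc2nc3c(c(Oc4cccc(NC(=O)/C=C/C(C)C)c4)n2)CSCC3)c1` differs from compound 2 as follows: isopropyl in place of methyl on a double-bonded chain carbon bound to a double-bonded chain carbon. Here, isopropyl stands in place of methyl on a double-bonded chain carbon bound to a double-bonded chain carbon. For the measured compounds named here, no measured step covers this place, so the expectation stays anchored on compound 2 at 21100 nM. The expected change is a 1.1-fold lower number from compound 2 to compound 3 (0.02 log units; within the scatter), with no step beyond the scatter anticipated in this assay. For compound 3 the estimated value is 20000 nM, with an expected range of 8000 nM to 45000 nM.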

Compound 3, half-maximal inhibitory concentration: 25300 nM
For compound 3 the middle estimate is 1.3-fold (0.10 log units) below the measured one, within the range that was stated.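

In this assay, the chain place gets its first measured step, which is a 1.2-fold higher number from compound 2 to compound 3 (0.08 log units; within the scatter). Going from methyl to isopropyl brings two more carbons, yet at this place the two compounds cannot be told apart in this read-out. The only other step shown, on the group on the aromatic nitrogen, lies beyond the scatter, and it rests on a limit of the assay rather than a number, since compound 1 sits at that limit: the limit of > 50000 nM in this assay, at which 1 of the 3 values shown sits.

On these data alone, what an amine such as dimethylamino, or a longer chain such as hexyl, would do at this same place stays open. As far as these compounds go, it is also open whether isopropyl would behave the same way with 1-methyl-1H-pyrazol-3-yl on the nitrogen in place of 3-methoxyphenyl.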